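A few compounds are considered here, and "the series" means these few. Any claim that something is new, unique, unknown or untested is made for them only; others in the source may bear on it.

In a functional assay on A549 cells (Homo sapiens) for inhibition, read by MTT assay, with a stated time of 72 h (a higher number here means a weaker inhibitor, a lower number a stronger inhibitor), three compounds built on one shared core have been measured. Compound 1 (`CC(C)c1ccc(NC(=O)C2CCN(C/C=C/c3ccccc3)CC2)cc1`) gives 9430 nM, compound 2 (`CCCCc1ccc(NC(=O)C2CCN(C/C=C/c3ccccc3)CC2)cc1`) gives 5910 nM, and compound 3 (`COc1cccc(NC(=O)C2CCN(C/C=C/c3ccccc3)CC2)c1`) gives 50500 nM, the highest of the three numbers. Compound 4 (`O=C(Nc1cccc(Br)c1)C1CCN(C/C=C/c2ccccc2)CC1`) has bromo in place of methoxy on an aromatic carbon, meta to a large group: bromo in place of methoxy on an aromatic carbon. For the measured compounds named here, no measured step makes this exact swap. The closest guide is a 5.4-fold higher number from compound 1 to compound 3 (0.73 log units; beyond the scatter), a modest change that came with 3-methoxyphenyl, while a 1.6-fold lower number from compound 1 to compound 2 (0.20 log units; within the scatter) shows that the alkyl swap hardly registers. Replacing the methoxy may therefore recover part of that gap. The expected change is a 3.0-fold lower number from compound 3 to compound 4 (0.47 log units; beyond the scatter), a modest step toward a lower number. For compound 4 the estimated value is 17000 nM, with an expected range from 6000 nM to 45000 nM.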

Compound 4, half-maximal inhibitory concentration: 16500 nM
The estimate for compound 4 lay 1.0-fold (0.01 log units) above the measured number; the measured number falls inside the stated range.
By their numbers in this assay, from the lowest: compounds 2, 1 and 4 (each within the scatter of the next, the first and the last beyond it); then compound 3.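

In this assay, swapping only the group on this aromatic carbon gives a 3.1-fold lower number from compound 3 to compound 4 (0.49 log units; beyond the scatter) and so shows that the high number of compound 3 goes with methoxy, not with substitution at this place as such. Moving to 3-bromophenyl from 4-isopropylphenyl gives a 1.7-fold higher number from compound 1 to compound 4 (0.24 log units; within the scatter) and leaves those two aryl groups not clearly separated. Nothing available explains the gap between methoxy and bromo. As far as these compounds go, whether chloro, an amine or a carboxylic acid on the same carbon would track bromo or methoxy remains open.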